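Fluoro to methoxy on the benzothiazole of compound 2

This account rests on a few compounds, and the source may have more. Where it says the series, first, only, none or still open, it means among the compounds named here.

Measured so far in a functional assay on HeLa cells (Homo sapiens) for cytotoxicity, read by MTT assay, with a stated time of 48 h; a lower number here means a stronger inhibitor, a higher number a weaker inhibitor:
- compound 1 `COc1ccc(-c2cc(C(=O)Nc3nc4ccc(F)cc4s3)nc3cc(-c4ccccc4)nn23)cc1OC`: 8310 nM
- compound 2 `COc1cc(-c2cc(C(=O)Nc3nc4ccc(F)cc4s3)nc3cc(-c4ccccc4)nn23)cc(OC)c1OC`: 25100 nM

Within the data shown here, compound 2 stands at the higher of the two numbers in this assay; the only measured step, a 3.0-fold higher number from compound 1 to compound 2 (0.48 log units; beyond the scatter), separates it from compound 1. Compound 3 `COc1ccc2nc(NC(=O)c3cc(-c4cc(OC)c(OC)c(OC)c4)n4nc(-c5ccccc5)cc4n3)sc2c1` has not yet been measured. It differs from compound 2 by methoxy in place of fluoro on an aromatic carbon.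

Among the measured compounds shown here, the single measured step concerns a different part of the shared core, where a methoxy replaced a hydrogen on the other aromatic ring; no measured pair touches the six-membered carbon-only ring of the fused two-ring system that is changed here. For the measured compounds named here, the step from compound 2 to compound 3 therefore has no direct precedent. Absent any bearing step, the expectation is no shift beyond the scatter, with the range kept wide to allow a move in either direction.

Compound 3 is estimated at 25000 nM, within 8000 nM to 80000 nM, which is expected to correspond to a 1.0-fold lower number from compound 2 to compound 3 (0.00 log units; within the scatter).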

Compound 3, half-maximal inhibitory concentration: 8700 nM
Compound 3: the middle estimate sits 2.9-fold (0.46 log units) above what was measured; the measured number falls inside the stated range.
By their numbers in this assay, from the lowest: compounds 1 and 3 (each within the scatter of the next); then compound 2.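

In this assay, the exchange of 6-fluoro-1,3-benzothiazol-2-yl for 6-methoxy-1,3-benzothiazol-2-yl gives a 2.9-fold lower number from compound 2 to compound 3 (0.46 log units; beyond the scatter) and so shows that this position, untouched by the earlier pair, can move the read-out beyond the scatter. The direction differs from that of the earlier methoxy step on the other aromatic ring, a 3.0-fold higher number from compound 1 to compound 2 (0.48 log units; beyond the scatter) where the number rose, so across these two steps a new methoxy does not push the number the same way at both places. No measured data bear on why the number fell at this position.

Open, from the compounds shown here alone, is whether the lower number is specific to methoxy or would also follow from another group at this place, such as an amine, a hydroxyl or a longer alkoxy chain like ethoxy. Also open, going by these compounds, is whether the same exchange would shift the number in the same direction on the core of compound 1, which carries one methoxy fewer on the other aromatic ring.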